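A few compounds are considered here, and "the series" means these few. Any claim that something is new, unique, unknown or untested is made for them only; others in the source may bear on it.

Measured compounds:
compound 1, `COc1cccc(CNCCCNc2ccnc3cc(Oc4ccc(F)cc4)ccc23)c1O`: 11000 nM
compound 2, `COc1cccc(CNCCCNc2ccnc3cc(-c4cccc5ccccc45)ccc23)c1O`: 2520 nM

Both compounds were examined in an ADME assay on HepG2 cells (Homo sapiens) for cytotoxicity, read by luminescence, CellTiter-Glo and ATP content, with a stated time of 72 h; on this read-out higher numbers stand for an effect only at larger amounts of compound and lower numbers for an effect already at smaller amounts. Compound 1 gives 11000 nM there, and compound 2 gives 2520 nM. Compound 2 thus stands at the lower of the two numbers, set apart from compound 1 by a 4.4-fold lower number from compound 1 to compound 2 (0.64 log units; beyond the scatter).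

The step under consideration leads from compound 2 to compound 3, `COc1ccc(-c2ccc3c(NCCCNCc4cccc(OC)c4O)ccnc3c2)cc1`, which has not yet been measured in this assay. The change is 4-methoxyphenyl in place of naphthalen-1-yl on an aromatic carbon.

For the measured compounds named here, only one measured step is at hand, and it does not repeat this exchange. It does show that a directly attached naphthalen-1-yl group, compared with 4-fluorophenoxy, went along with a 4.4-fold lower number from compound 1 to compound 2 (0.64 log units; beyond the scatter). Compound 3 keeps a directly attached aromatic ring, but a single one, 4-methoxyphenyl, so he expects the number to move partly back toward that of compound 1, with a modest rise for compound 3 estimated as a 2.0-fold higher number from compound 2 to compound 3 (0.30 log units; within the scatter). His estimate for compound 3 in this assay is 5000 nM, with an expected range from 2000 nM to 13000 nM.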

Compound 3, half-maximal effective concentration: 1600 nM
For compound 3 the middle estimate is 3.1-fold (0.49 log units) above the measured one, outside the stated range (below it).
By their numbers in this assay, from the lowest: compounds 3 and 2 (each within the scatter of the next); then compound 1.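

In this assay, 4-methoxyphenyl in place of naphthalen-1-yl gives a 1.6-fold lower number from compound 2 to compound 3 (0.20 log units; within the scatter), so at this position a group with one six-membered aromatic ring of carbon only and 8 heavy atoms cannot be told apart from one with two such rings and 10 heavy atoms. The second ring of naphthalen-1-yl is therefore not needed to reach this range of numbers, at least when a methoxy group is present on the remaining ring. The other step, a 6.9-fold lower number from compound 1 to compound 3 (0.84 log units; beyond the scatter), shows that a second, different directly attached aromatic group also stands clear of the 4-fluorophenoxy compound, so compounds 2 and 3 agree on this point, although the evidence at hand does not say what lies behind it.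

The compounds shown leave open whether the methoxy group of compound 3 contributes anything, which a plain phenyl ring or a 4-fluorophenyl ring at the same carbon could test. They also leave open how a ring carrying an amine or a carboxylic acid would read here, and whether a longer chain on the shared core would change these numbers.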